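The source may hold more compounds than are shown below. What is called first, only, known or untested is meant among the compounds shown, and "the series" means these compounds.

Measured in a functional assay on B16-F0 cells (Mus musculus) for inhibition, read by CCK-8 assay, with a stated time of 48 h; a lower number here means a stronger inhibitor, a higher number a weaker inhibitor:
Compound 1 `COc1cc(-c2ccnc3cc(-c4ccc5c(ccn5C)c4)nn23)cc(OC)c1OC`: 48 nM
Compound 2 `COc1cc(-c2ccnc3cc(-c4ccc(C(F)(F)F)cc4)nn23)cc(OC)c1OC`: 1770 nM

Compound 2 has the higher of the two numbers, making it the weaker inhibitor. Compound 3 `COc1cc(-c2ccnc3cc(-c4cccc(C)c4)nn23)cc(OC)c1OC` changes the same aromatic carbon: 3-methylphenyl in place of 4-(trifluoromethyl)phenyl, (3-methylphenyl in place of 4-(trifluoromethyl)phenyl on an aromatic carbon). For the measured compounds named here, only one measured step bears on this carbon, a 37-fold higher number from compound 1 to compound 2 (1.57 log units; beyond the scatter), which is large and beyond the scatter. It shows that the number can respond strongly to the group here, but it involves a different replacement. A smaller move towards a lower number therefore seems likely. The expected step is a 3.0-fold lower number from compound 2 to compound 3 (0.47 log units; beyond the scatter). For compound 3, the estimated value is 600 nM, with an expected range of 150 nM to 2500 nM.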

Compound 3, half-maximal inhibitory concentration: 2220 nM
The estimate for compound 3 lay 3.7-fold (0.57 log units) below the measured number; the measured number falls inside the stated range.
By their numbers in this assay, from the lowest: compound 1; then compounds 2 and 3 (each within the scatter of the next).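

In this assay, the change to 3-methylphenyl gives a 1.3-fold higher number from compound 2 to compound 3 (0.10 log units; within the scatter), so this replacement separates neither group from the other, even though the substituent and its place on the phenyl ring both differ. Against the 1-methyl-1H-indol-5-yl group, it gives a 46-fold higher number from compound 1 to compound 3 (1.67 log units; beyond the scatter), so the large gap now appears with two different substituted phenyl groups. Nothing available explains this gap. Going by these compounds, it remains open whether a phenyl group carrying an amine or a carboxylic acid would behave like these two. Also open, on these data alone, is whether an indol-5-yl group without its methyl would keep the lower number of compound 1.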